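This account rests on a few compounds, and the source may have more. Where it says the series, first, only, none or still open, it means among the compounds named here.

Measured so far in an assay on isolated protein for inhibition of Amine oxidase [flavin-containing] B (Homo sapiens), read by fluorescence, with a stated time of 1 h, tested at 10 uM; a lower number here means less inhibition, a higher number more inhibition at the concentration tested (going by the name of the read-out):

Compound 1 `c1ccc(-c2nc3ccc(N4CCCCCC4)nc3o2)cc1`: 57.9%
Compound 2 `Fc1cccc(-c2nc3ccc(N4CCCCC4)nc3o2)c1`: 89.7%
Compound 3 `c1ccc(-c2nc3ccc(N4CCCCC4)nc3s2)cc1`: 95.5%

Compound 3 gives the highest of the three numbers. Its nearest neighbour on the numbers is compound 2, whose value lies within the scatter of compound 3, so the two cannot be put in order. Compound 1 stands clearly lower than compound 3, a gap beyond the scatter. Going by the values given here, no two of the three measured compounds differ in only one place, so no single step between them can be read off.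

Compound 4 `Clc1ccccc1-c1nc2ccc(N3CCCCC3)nc2s1` is the next compound to be measured in this assay. It differs from compound 3 in one place: chloro in place of hydrogen on an aromatic carbon. The site of the change is ortho to a large group on the six-membered ring of carbon only; the same difference, read one bond further out, is phenyl to 2-chlorophenyl.

Among the compounds with values here, since compound 3 already gives 95.5%, little room remains above it, and no measured pair tells how a chloro at this position acts. The expectation is therefore a step of no more than the scatter, in either direction, from compound 3 to compound 4: a number 5.5 percentage points lower from compound 3 to compound 4 (within the scatter) is what the estimate means. Compound 4 is expected to give about 90% in this assay, within a range of 70% to 99%.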

Compound 4, a percentage reported as inhibition, at one concentration (the size of the read-out at that concentration, not a potency): 95.1%
Compound 4: the middle estimate sits 5.1 percentage points below what was measured, and the stated range covers the measured number.
By their numbers in this assay, from the lowest: compound 1; then compounds 2, 4 and 3 (each within the scatter of the next).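

Chloro in place of hydrogen on an aromatic carbon of the six-membered aromatic ring of carbon only, ortho to a large group, gives the first one-place step in the series in this assay: a number 0.4 percentage points lower from compound 3 to compound 4 (within the scatter). A chloro can therefore stand at this place without a shift beyond the scatter, although compound 3 and compound 4 both lie close to the top of the percentage scale, where a single tested concentration has little room to separate compounds. No measurement at hand offers an explanation for this step.

Open, going by these compounds, is whether a methoxy group, a carboxylic acid or an amine at this same place would also hold the number in this assay, and whether a dose-response measurement would separate compound 3 from compound 4. The other differences among compound 1, compound 2 and compound 3 cannot be read as single steps, so the contributions of the core and of the saturated amine ring remain unresolved.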